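Cyclohexyloxy to Benzyloxy on the Shared Core

This account rests on a few compounds, and the source may have more. Where it says the series, first, only, none or still open, it means among the compounds named here.

Measured compounds:
compound 1 `CCCN(CCC)c1nc(C(C)(C)C)ccc1CNC(=O)C(C)c1ccc(NS(C)(=O)=O)c(F)c1` — 2.5 nM
compound 2 `CC(C(=O)NCc1ccc(C(C)(C)C)nc1OC1CCCCC1)c1ccc(NS(C)(=O)=O)c(F)c1` — 2.5 nM

In an assay on cells for antagonist activity at transient receptor potential cation channel subfamily V member 1 (Homo sapiens), read by FLIPR and calcium flux, with a stated time of 6 min (on this read-out higher numbers stand for weaker inhibition and lower numbers for stronger inhibition), compound 2 gives 2.5 nM, level with compound 1 at the digits shown. Compound 3 `CC(C(=O)NCc1ccc(C(C)(C)C)nc1OCc1ccccc1)c1ccc(NS(C)(=O)=O)c(F)c1` is not yet measured; it differs from compound 2 by benzyl in place of cyclohexyl on an oxygen on an aromatic ring. Going by the values given here, one measured step touches the same part of the shared core: no change at the digits printed from compound 1 to compound 2 (within the scatter), no change within the scatter. On that footing compound 3 is expected to stay close to compound 2, with a shift of a 1.6-fold higher number from compound 2 to compound 3 (0.20 log units; within the scatter) expected, or none beyond the scatter. The estimate for compound 3 is 4 nM, ranging from 1.5 nM to 12 nM.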

Compound 3, inhibition constant: 4.4 nM
Beside the measured number, compound 3's estimate is 1.1-fold (0.04 log units) below it; low and high end bracket the measured number.
By their numbers in this assay, from the lowest: compounds 1, 2 and 3 (each within the scatter of the next).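

Replacing cyclohexyl with benzyl on this oxygen gives a 1.8-fold higher number from compound 2 to compound 3 (0.25 log units; within the scatter) in this assay, so a six-membered aromatic ring of carbon serves here as well as a non-aromatic one. Set against the dipropylamino group, benzyloxy gives a 1.8-fold higher number from compound 1 to compound 3 (0.25 log units; within the scatter) and so all three groups tested at this place read alike. Nothing measured here offers a reason for this sameness. Going by these compounds, what stays open is whether the same holds for a methoxy group, or for a chain ending in a carboxylic acid or an amine.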